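The source may report more compounds than this note shows. Statements on the series, on what has been measured and on what is new or still open speak of the compounds shown alone.

Two closely related compounds have been measured in a functional assay on PC-3 cells (Homo sapiens) for inhibition; a higher number here means a weaker inhibitor, a lower number a stronger inhibitor. Compound 1, `COc1cc2nc(N3CCN(S(=O)(=O)c4ccc(Cl)cc4)CC3)nc(N)c2cc1OC`, gives 23000 nM. Compound 2, `COc1cc2nc(N3CCN(S(=O)(=O)c4ccc(C(=O)O)cc4)CC3)nc(N)c2cc1OC`, gives 53000 nM. Among the measured compounds shown here, the only change between them is a carboxy group in place of a chloro group on an aromatic carbon, and that step, a 2.3-fold higher number from compound 1 to compound 2 (0.36 log units; beyond the scatter), moved the number up, meaning a weaker inhibitor. For the measured compounds named here, compound 2 therefore stands as the higher of the two numbers measured so far in this assay.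

Compound 3, `COc1cc2nc(N3CCN(S(=O)(=O)c4ccc(-c5ccc(C(F)(F)F)cc5)cc4)CC3)nc(N)c2cc1OC`, keeps the shared core and the sulfonyl-linked aromatic ring but replaces the carboxy group: 4-(trifluoromethyl)phenyl in place of carboxy on an aromatic carbon. Going by the values given here, no measured step covers this exact exchange. Among the compounds with values here, the one step that bears on it, the move from compound 1 to compound 2, shows that removing the carboxy group in favour of a group without hydrogen-bond donors or acceptors gave a modestly lower number. On that basis compound 3 is expected to give a lower number than compound 2 in this assay, by a modest step, a 3.5-fold lower number from compound 2 to compound 3 (0.55 log units; beyond the scatter). The estimate for compound 3 is 15000 nM, with a range from 3000 nM to 60000 nM.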

Compound 3, half-maximal inhibitory concentration: 3300 nM
Estimate against measurement, compound 3: 4.5-fold (0.66 log units) above, within the range that was stated.
By their numbers in this assay, from the lowest: compound 3; then compound 1; then compound 2.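

In this assay, among the compounds shown here, this aromatic carbon, para to a large group, accepts a much larger substituent than the earlier compounds carried, and the number falls rather than rises. 4-(Trifluoromethyl)phenyl, with 10 heavy atoms and its own six-membered aromatic ring, gives a 16-fold lower number from compound 2 to compound 3 (1.21 log units; beyond the scatter) in place of carboxy, a large step, and a 7.0-fold lower number from compound 1 to compound 3 (0.84 log units; beyond the scatter) in place of chloro, a modest one. The earlier pair showed only a modest shift at this position, whereas compound 3 shows that a change here can move the number much further and now has the lowest number of the three, though nothing available explains the gain.

The compounds shown leave open whether the lower number goes with the added aromatic ring itself or with the trifluoromethyl group it carries, a question that a plain phenyl group at this position would help to separate. They also leave open whether a ring is needed at all, or whether a butyl chain or a ring bearing an amine, such as 4-aminophenyl, would give a similar number.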